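A few compounds are considered here, and "the series" means these few. Any claim that something is new, unique, unknown or untested is made for them only; others in the source may bear on it.

Measured compounds:
compound 1, `COc1ccc(C2SCC(=O)N2n2c(CSc3nnc(-c4ccncc4)o3)nc3ccccc3c2=O)cc1`, 33.8%
compound 2, `COc1ccc(C2SCC(=O)N2n2c(CSc3nnc(-c4ccncc4)o3)nc3ccc(Br)cc3c2=O)cc1`, 35.3%
compound 3, `O=c1c2cc(Br)ccc2nc(CSc2nnc(-c3ccncc3)o2)n1/N=C/c1ccccc1`, 19.4%

The three measured compounds were tested in a functional assay on the whole organism (strain Charles-Foster albino) for inhibition, with Rattus norvegicus as the target, read by paw edema, at a dose of 50 mg/kg by the oral route; a higher number here means more inhibition at the dose given (going by the name of the read-out), a lower number less inhibition. Compound 1 gives 33.8% and compound 2 gives 35.3%; the two differ by hydrogen in place of bromo on an aromatic carbon, and the step of a number 1.5 percentage points lower from compound 2 to compound 1 (within the scatter) lies within the scatter, so the two values show no difference that can be trusted. Compound 3 gives 19.4%, which is the lowest of the three numbers, and its gap to compound 1 and to compound 2 is beyond the scatter. How the core of compound 3 differs from the core of compound 2 is not broken down here.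

Compound 4, `O=c1c2ccccc2nc(CSc2nnc(-c3ccncc3)o2)n1/N=C/c1ccccc1`, has not yet been measured in this assay. It differs from compound 3 by hydrogen in place of bromo on an aromatic carbon. Going by the values given here, this is the same kind of change as the one from compound 2 to compound 1, and the place described for it is the same in both cases. Because that earlier step was a number 1.5 percentage points lower from compound 2 to compound 1 (within the scatter), the value of compound 4 is expected to stay close to that of compound 3, and the step of a number 1.4 percentage points lower from compound 3 to compound 4 (within the scatter) is estimated to be small. Compound 4 is therefore expected to give about 18% in this assay, with the estimate ranging from 8% to 28%.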

Compound 4, a percentage reported as inhibition, in the whole organism at one dose (the size of the read-out at that dose, not a potency): 16.3%
Compound 4: the middle estimate sits 1.7 percentage points above what was measured; the measured number falls inside the stated range.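

In this assay, putting hydrogen in place of bromo on the aromatic carbon of the second core gives a number 3.1 percentage points lower from compound 3 to compound 4 (within the scatter), so on this core too the exchange produces no difference that can be trusted. Set beside the earlier case, the step carries over from one core to the other, and the two cores cannot be told apart in their response to this change: the same change on two cores in this assay, a number 1.5 percentage points lower (within the scatter) from compound 2 to compound 1 and a number 3.1 percentage points lower (within the scatter) from compound 3 to compound 4, 1.6 percentage points apart, within the scatter of two such steps This does not show that bromo and hydrogen are truly equivalent at this place, since a small real effect could lie hidden within the scatter of both steps, and the agreement rests on only two cores, one read-out and a single oral dose, so it cannot be extended to other cores or other doses.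

The compounds shown hold only bromo or hydrogen at this place on the ring, so it remains open whether a chloro group, a methoxy group, an amine or a carboxylic acid there would also leave the inhibition of paw edema unchanged. On these data alone, it also remains open whether the two cores would still respond alike to any of these groups.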